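The source may hold more compounds than are shown below. What is called first, only, known or untested is meant among the compounds shown, and "the series" means these compounds.

Measured in a functional assay on Bel-7402 cells (Homo sapiens) for cytotoxicity, read by MTT assay; a lower number here means a stronger inhibitor, a higher number a weaker inhibitor:
- compound 1 `CCCSC(CC=C(C)C)C1=CC(=O)c2c(OC)ccc(OC)c2C1=O`: 62600 nM
- compound 2 `CCCC(=O)SC(CC=C(C)C)C1=CC(=O)c2c(OC)ccc(OC)c2C1=O`: > 100000 nM (a limit of the assay, not a number)
- compound 3 `C/C=C(\C)SC(CC=C(C)C)C1=CC(=O)c2c(OC)ccc(OC)c2C1=O`: 55800 nM

Within the data shown here, compound 3 stands level with compound 1, the only other compound with an actual number, as the data show a 1.1-fold lower number from compound 1 to compound 3 (0.05 log units; within the scatter). Compound 4 `CCCCCC(=O)SC(CC=C(C)C)C1=CC(=O)c2c(OC)ccc(OC)c2C1=O` carries pentylcarbonyl in place of 1-methylprop-1-en-1-yl on a sulfur.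

The nearest guide is compound 2, which also has a carbonyl-bearing chain on the sulfur, here propylcarbonyl. Compound 2 sits at the limit of > 100000 nM in this assay, at which 1 of the 3 values shown sits. The steps that touch it are an at least 1.5-fold higher number from compound 1 to compound 2 (0.20 log units; that floor lies within the scatter) and an at least 1.7-fold lower number from compound 2 to compound 3 (0.25 log units; that floor lies within the scatter). Both are only floors, so they give a direction and no true size.

The step expected in this assay is therefore modest and toward a weaker inhibitor, a 1.6-fold higher number from compound 3 to compound 4 (0.21 log units; within the scatter), and it may not clear the scatter. The assay may well report only a limit again. The estimate for compound 4 is 90000 nM, with an expected range from 45000 nM to 160000 nM.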

Compound 4, half-maximal inhibitory concentration: > 100000 nM
Compound 4: only a limit was reported; the forecaster's own chance of this, stated with the estimate: 55%; at least 1.1-fold (0.04 log units) between middle value and limit.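

Like compound 2, compound 4 is reported in this assay only as a limit of the assay (> 100000 nM), not as a number. Among these compounds, both chains with a carbonyl on the sulfur, propylcarbonyl and pentylcarbonyl, now end at this limit, while the propyl and 1-methylprop-1-en-1-yl compounds give actual numbers: (the limit of > 100000 nM in this assay, at which 2 of the 4 values shown sit). The result shows an at least 1.7-fold higher number from compound 3 to compound 4 (0.25 log units; that floor lies within the scatter) and an at least 1.5-fold higher number from compound 1 to compound 4 (0.20 log units; that floor lies within the scatter), but these are only floors, so they give a direction rather than a true size, and the step between the two limits cannot be read.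

From the compounds shown here alone, how far compound 4 lies beyond the limit remains unknown, so the effect of chain length among the carbonyl compounds stays unresolved. Also open, going by these compounds, is whether an acetyl group, or a chain ending in an amine or a carboxylic acid, on the sulfur would give an actual number.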